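Working notes: from compound 3 to compound 4

The source may report more compounds than this note shows. Statements on the series, on what has been measured and on what is new or still open speak of the compounds shown alone.

Measured in a physicochemical assay for solubility, read by chemiluminescence, measured as kinetic solubility; on this read-out higher numbers stand for higher solubility and lower numbers for lower solubility:
- Compound 1 `Cn1ncc2c(NS(=O)(=O)c3cccc(Cl)c3Cl)cccc21`: 170000 nM
- Compound 2 `O=S(=O)(Nc1ncnc2[nH]nc(O)c12)c1cccc(Cl)c1Cl`: >= 234000 nM (a limit)
- Compound 3 `COc1nn(C)c2nc(C)nc(NS(=O)(=O)c3cccc(Cl)c3Cl)c12`: >= 557000 nM (a limit)

Compound 3 stands at the limit of >= 557000 nM in this assay, at which 1 of the 3 values shown sits, so it offers a limit and no number. Compound 4 `CNc1nc(NS(=O)(=O)c2cccc(Cl)c2Cl)c2c(OC)nn(C)c2n1` carries methylamino in place of methyl on an aromatic carbon, between two ring nitrogen atoms (methylamino in place of methyl on an aromatic carbon). For the measured compounds named here, no measured pair differs in one place, so this step has no direct precedent. A small downward move, within the usual scatter, is expected, and the expected step is an at least 1.8-fold lower number from compound 3 to compound 4 (0.26 log units; that floor lies within the scatter). Going by the values given here, compound 1 at 170000 nM gives the only exact number and informs the lower side of the expectation. Compound 4 is estimated at 300000 nM, with an expected range of 100000 nM to 700000 nM.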

Compound 4, solubility: 376000 nM
Beside the measured number, compound 4's estimate is 1.3-fold (0.10 log units) below it; measured number inside the range.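

In this assay, methylamino in place of methyl on an aromatic carbon, between two ring nitrogen atoms, gives the series its first step in one place, an at least 1.4-fold lower number from compound 3 to compound 4 (0.17 log units; that floor lies within the scatter). Compound 3 offers only a limit, so this step has a floor and no exact size: the limit of >= 557000 nM in this assay, at which 1 of the 4 values shown sits. As that floor lies within the scatter, no real change at this position is established.

On these data alone, the true size of the step remains open. Also open, as far as these compounds go, is how dimethylamino or a carboxylic acid on this carbon would read.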